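Swapping tert-butyl for phenyl: expected cell tolerance

The source may report more compounds than this note shows. Statements on the series, on what has been measured and on what is new or still open speak of the compounds shown alone.

Values in a toxicity assay on Vero C1008 cells (Chlorocebus sabaeus) for cytotoxicity, read by neutral red uptake, with a stated time of 5 days (a higher number here means that more compound is tolerated, a lower number that less compound is tolerated), for the three measured compounds:
Compound 1 `CC(C)(C)c1ccc(N(C(=O)c2ccco2)C(C(=O)NC2CCCC2)c2cccnc2)cc1`: 101000 nM
Compound 2 `CC(C)(C)c1ccc(N(C(=O)c2ccco2)C(C(=O)NC2CCCCC2)c2cccnc2)cc1`: 18200 nM
Compound 3 `C[C@H](NC(=O)C(c1cccnc1)N(C(=O)c1ccco1)c1ccc(-c2ccco2)cc1)c1ccccc1`: 56400 nM

Compound 2 gives the lowest number of the three in this assay, so it is the least tolerated; compound 3 sits closer to it and compound 1 furthest away. Going by the values given here, the only step between neighbours is a 5.5-fold lower number from compound 1 to compound 2 (0.74 log units; beyond the scatter), and that step changes the group on the amide nitrogen, not the part altered next.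

Compound 4 `O=C(NC1CCCCC1)C(c1cccnc1)N(C(=O)c1ccco1)c1ccc(-c2ccccc2)cc1` differs from compound 2 in one place: phenyl in place of tert-butyl on an aromatic carbon, which read one bond further out is 4-(tert-butyl)phenyl to 4-phenylphenyl. Among the compounds with values here, no measured step bears on this exchange. Compound 3 also carries a ring in this position, but it differs from compound 2 at the amide nitrogen as well, so its value cannot be assigned to either change. With nothing to point in a direction, no step beyond the scatter is expected in this assay.

Compound 4 is therefore estimated at 25000 nM, within 9000 nM to 70000 nM, a step of a 1.4-fold higher number from compound 2 to compound 4 (0.14 log units; within the scatter).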

Compound 4, half-maximal cytotoxic concentration: 53500 nM
Estimate against measurement, compound 4: 2.1-fold (0.33 log units) below; the range from low to high includes it.
By their numbers in this assay, from the lowest: compound 2; then compounds 4, 3 and 1 (each within the scatter of the next).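

In this assay, this position on the aromatic ring, para to a large group, proves able to shift the result: phenyl in place of tert-butyl gives a 2.9-fold higher number from compound 2 to compound 4 (0.47 log units; beyond the scatter), a move towards more compound being tolerated. Going by these compounds alone, the earlier clean step showed a change only at the amide nitrogen, so this is the first sign that a change on the far side of the molecule counts too. Nothing shown gives a reason for this shift.

From the compounds shown here alone, the step comes from a single pair with cyclohexyl on the amide nitrogen, so it remains open whether the same exchange would act alike with cyclopentyl there. Also open, going by these compounds, is how a methoxy group, an amine or a carboxylic acid at this position would compare with phenyl and tert-butyl.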